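Sulfonamide series: 3-hydroxyphenyl to 3,4-dichlorophenyl exchange

The source may report more compounds than this note shows. Statements on the series, on what has been measured and on what is new or still open speak of the compounds shown alone.

In an assay on isolated protein for inhibition of malate dehydrogenase, mitochondrial (Sus scrofa), with stated times of 45 min and 30 min (on this read-out lower numbers stand for stronger inhibition and higher numbers for weaker inhibition), compound 1 `O=S(=O)(Nc1ccc(-c2nc3ccccc3o2)cc1)c1cccc(O)c1` gives only a limit, > 63000 nM. Compound 2 `CS(=O)(=O)Nc1ccc2oc(-c3ccccc3)nc2c1` likewise gives only a limit in this assay, > 63000 nM. Within the data shown here, compound 1 thus stands at the limit of > 63000 nM in this assay, at which 2 of the 2 values shown sit, and no step between measured compounds is known. Compound 3 `O=S(=O)(Nc1ccc(-c2nc3ccccc3o2)cc1)c1ccc(Cl)c(Cl)c1` differs from compound 1 by 3,4-dichlorophenyl in place of 3-hydroxyphenyl on a sulfonyl sulfur. Given that compound 1 sits at its limit > 63000 nM, the step that the limit leaves unreadable from compound 1 to compound 3 is expected to be none beyond the scatter. Compound 3 is therefore estimated at 80000 nM in this assay, within a range of 20000 nM to 300000 nM, most probably reported again only as a limit.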

Compound 3, half-maximal inhibitory concentration: > 63000 nM
Compound 3 ended at the assay's limit; the forecaster's own chance of this, stated with the estimate: 75%; the middle value is on the limit's open side.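

Compound 1 and compound 3 both sit at a limit, so no step between them can be read: the limit of > 63000 nM in this assay, at which 3 of the 3 values shown sit.

The compounds shown leave open which structural change, if any, would give a numerical value in this assay.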